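Trimming the side chain of compound 2

A few compounds are considered here, and "the series" means these few. Any claim that something is new, unique, unknown or untested is made for them only; others in the source may bear on it.

Compound 1 `CNC(=O)c1ccc(=O)n(Cc2cc(Br)ccc2F)c1` (>= 143 ug/mL)
Compound 2 `CNC(=O)c1cc(C(=O)NCCCC2CNCCO2)cn(Cc2ccccc2)c1=O` (>= 194 ug/mL)

Both compounds were tested in a physicochemical assay for solubility (a higher number here means a more soluble compound, a lower number a less soluble compound), and both gave only a limit, not a number. Compound 2 stands at its limit (>= 194 ug/mL). Compound 3 `CCNC(=O)c1cc(C(=O)NC)c(=O)n(Cc2ccccc2)c1` differs from compound 2 by hydrogen in place of (morpholin-2-yl)methyl on a saturated chain carbon, two bonds along the chain from an amide-type nitrogen with hydrogen in place of (morpholin-2-yl)methyl on a saturated chain carbon, two bonds along the chain from an amide-type nitrogen. Within the data shown here, no measured step shows what this change does in this assay and little change beyond the scatter is expected, with a slight fall at most. The expected step is small (an at least 1.2-fold lower number from compound 2 to compound 3 (0.11 log units; that floor lies within the scatter)). Compound 3 is estimated at 150 ug/mL with an expected range of 70 ug/mL to 230 ug/mL.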

Compound 3, solubility: >= 144 ug/mL
Compound 3 gave a limit, no number (the forecaster's own chance of this, stated with the estimate: 50%); the middle value is on the limit's open side.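

Among these compounds, compound 2 and compound 3 each gave only a limit in this assay, so no step between them can be read. The compounds shown leave open whether going from 3-(morpholin-2-yl)propyl to ethyl shifts the result in this assay at all.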